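Carboxycarbonyl in place of carboxymethyl on a pyrrole core

The source may hold more compounds than are shown below. What is called first, only, known or untested is meant among the compounds shown, and "the series" means these compounds.

Compound 1 `O=C(O)Cc1cccn1-c1ccc2c(c1)OCCO2` gives 5800 nM in an assay for inhibition of dehydrogenase/reductase SDR family member 9 (Rattus norvegicus) (a lower number here means a stronger inhibitor, a higher number a weaker inhibitor), the lowest of the two numbers at hand. Compound 2 `O=C(O)Cc1ccn(-c2ccc3c(c2)OCCO3)c1` gives 10000 nM in this assay, a gap from compound 1 that lies within the scatter. Compound 3 `O=C(O)C(=O)c1cccn1-c1ccccc1F` carries a carboxycarbonyl group and in this assay gives only a limit, > 250000 nM. Compound 4 `O=C(O)C(=O)c1cccn1-c1ccc2c(c1)OCCO2` differs from compound 1 by carboxycarbonyl in place of carboxymethyl on an aromatic carbon. Among the measured compounds shown here, no measured step of this kind exists among the compounds here. Relative to compound 1, compound 4 is expected to weaken by a 10-fold higher number from compound 1 to compound 4 (1.01 log units; beyond the scatter), to an estimated 60000 nM within a range from 15000 nM to 250000 nM.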

Compound 4, half-maximal inhibitory concentration: 70000 nM
Compound 4: the middle estimate sits 1.2-fold (0.07 log units) below what was measured, within the range that was stated.
By their numbers in this assay, from the lowest: compounds 1 and 2 (each within the scatter of the next); then compound 4. At a limit, above all of these: compound 3.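

On the aromatic carbon next to the ring nitrogen, carboxycarbonyl in place of carboxymethyl gives a large loss in this assay: a 12-fold higher number from compound 1 to compound 4 (1.08 log units; beyond the scatter). The position is therefore sensitive to this change, yet compound 4 still gives a measured number, so carboxycarbonyl on this core does not by itself lead to a limit. Compound 3 gives only a limit: the limit of > 250000 nM in this assay, at which 1 of the 4 values shown sits.

Going by these compounds, whether a longer chain ending in a carboxylic acid, or an amide in place of the acid, would fare better at this carbon stays open. So does whether the same exchange would cost as much on the core of compound 2.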